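Swapping cyano for phenoxy on a weak inhibitor

This account rests on a few compounds, and the source may have more. Where it says the series, first, only, none or still open, it means among the compounds named here.

Values in a functional assay on Jurkat cells (Homo sapiens) (a higher number here means a weaker inhibitor, a lower number a stronger inhibitor), for the compounds measured so far:
- compound 1 `CC(C)[C@H](NC(=O)COc1cccc2ccccc12)C(=O)N[C@@H](CC(=O)O)C(=O)COc1ccccc1` gives 14000 nM
- compound 2 `CC(C)[C@H](NC(=O)COc1cccc2ccccc12)C(=O)N[C@@H](CC(=O)O)C(=O)COc1ccc(-c2ccccc2)cc1` gives 87900 nM
- compound 3 `CC(C)[C@H](NC(=O)COc1cccc2ccccc12)C(=O)N[C@@H](CC(=O)O)C(=O)COc1ccc(C#N)cc1` gives > 100000 nM (a limit of the assay, not a number)

Compound 3 stands at > 100000 nM, and that reading is a limit of the assay. The next compound, compound 4 `CC(C)[C@H](NC(=O)COc1cccc2ccccc12)C(=O)N[C@@H](CC(=O)O)C(=O)COc1ccc(Oc2ccccc2)cc1`, carries phenoxy in place of cyano on an aromatic carbon, para to a large group: phenoxy in place of cyano on an aromatic carbon.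

Among the measured compounds shown here, three measured steps bear on this change. Two start from the hydrogen of compound 1: a 6.3-fold higher number from compound 1 to compound 2 (0.80 log units; beyond the scatter) and an at least 7.1-fold higher number from compound 1 to compound 3 (0.85 log units; beyond the scatter). Both are modest and beyond the scatter, and both lead to a higher number. The third, an at least 1.1-fold higher number from compound 2 to compound 3 (0.05 log units; that floor lies within the scatter), has a floor within the scatter, so phenyl and cyano cannot be told apart here.

Phenoxy brings an aromatic ring, as phenyl does, so compound 4 is expected to sit near compound 2 at 87900 nM. In this assay a small move to a lower number is therefore expected, possibly none beyond the scatter. The expected step is an at least 1.4-fold lower number from compound 3 to compound 4 (0.15 log units; that floor lies within the scatter). For compound 4 the estimate is 70000 nM, with an expected range from 28000 nM to 100000 nM.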

Compound 4, half-maximal inhibitory concentration: 12700 nM
For compound 4 the middle estimate is 5.5-fold (0.74 log units) above the measured one; measured number outside the range, below it.
By their numbers in this assay, from the lowest: compounds 4 and 1 (each within the scatter of the next); then compound 2. At a limit, above all of these: compound 3.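

In this assay, this position separates two groups that each bring an aromatic ring, since the oxygen-linked ring of phenoxy and the directly attached phenyl give clearly different results: a 6.9-fold lower number from compound 2 to compound 4 (0.84 log units; beyond the scatter). Phenoxy also reads the same as the plain hydrogen of compound 1, a 1.1-fold lower number from compound 1 to compound 4 (0.04 log units; within the scatter), so a large group here is not penalised in every case, while phenyl in compound 2 and cyano in compound 3 both go against any simple rule that adding a group is tolerated or that adding one costs activity. Compound 3 sits at a limit of the assay, so the step of an at least 7.8-fold lower number from compound 3 to compound 4 (0.89 log units; beyond the scatter) gives only a floor and its full size is unknown: the limit of > 100000 nM in this assay, at which 1 of the 4 values shown sits.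

No group shown at this position gives a number lower than that of compound 1 beyond the scatter, so it remains open whether any substituent here can do so. As far as these compounds go, whether a small group such as methoxy or an amine would read like phenoxy or like phenyl also remains open, as does whether the oxygen alone or the oxygen together with its ring sets the result for compound 4.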